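Replacing chloro with nitro on the shared core

The source may hold more compounds than are shown below. What is called first, only, known or untested is meant among the compounds shown, and "the series" means these compounds.

Of the compounds shown here, two have been tested so far. Compound 1 `CN(C)c1ccc(/C=N/NC(=O)Nc2cccc3ccccc23)cc1` gives 100 mg/kg in a functional assay on the whole organism (strain Swiss albino) with Mus musculus as the target, in the maximal electroshock model, with a stated time of 4 h (a higher number here means that more compound is needed for the effect, a lower number that less compound is needed), while compound 2 `O=C(N/N=C/c1ccc(Cl)cc1)Nc1cccc2ccccc12` gives 300 mg/kg, the higher of the two numbers in this assay. Among the measured compounds shown here, the single step between them, a 3.0-fold higher number from compound 1 to compound 2 (0.48 log units; beyond the scatter), comes from chloro in place of dimethylamino on an aromatic carbon of the core.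

Compound 3 `O=C(N/N=C/c1ccc([N+](=O)[O-])cc1)Nc1cccc2ccccc12` is not yet measured. It differs from compound 2 by nitro in place of chloro on an aromatic carbon, the new group sitting on an aromatic carbon of a six-membered aromatic ring of carbon only, para to a large group. For the measured compounds named here, no measured step in this assay involves a nitro group, so nothing here speaks directly to the change. Going by the values given here, the one known step, from dimethylamino to chloro, was modest, and the new step is of a different kind, so it is expected that the number for compound 3 will not move beyond the scatter, with no change at the digits printed from compound 2 to compound 3 (within the scatter) as the expected step. Compound 3 is therefore estimated at 300 mg/kg, within a range of 100 mg/kg to 900 mg/kg.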

Compound 3, minimum effective dose: 300 mg/kg
Beside the measured number, compound 3's estimate shows no gap at the digits printed; the range from low to high includes it.
By their numbers in this assay, from the lowest: compound 1; then compounds 2 and 3 (each within the scatter of the next).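

In this assay, nitro in place of chloro, on an aromatic carbon para to a large group, gives no change at the digits printed from compound 2 to compound 3 (within the scatter) and so leaves the number where it stood, although the entering group has more heavy atoms and adds hydrogen-bond acceptors. The second new step, a 3.0-fold higher number from compound 1 to compound 3 (0.48 log units; beyond the scatter) for nitro in place of dimethylamino, matches in size the earlier step of a 3.0-fold higher number from compound 1 to compound 2 (0.48 log units; beyond the scatter) for chloro in place of dimethylamino, so among these three compounds only compound 1, which carries dimethylamino, stands apart at this place. Nothing available bears on why the numbers fall this way.

From the compounds shown here alone, whether that lower number belongs to dimethylamino alone or would also appear with a simple amine, a methoxy group or a carboxylic acid at this place stays open. The compounds shown also leave open how a group in any other place on the shared core would shift the number, and whether the match between chloro and nitro would hold there.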